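The source may report more compounds than this note shows. Statements on the series, on what has been measured and on what is new or still open speak of the compounds shown alone.

Compound 1, `COc1cc(-c2cc(COCc3cn(Cc4cc(-c5ccccc5)cnc4Cl)nn3)on2)cc(OC)c1OC`: 68500 nM
Compound 2, `COc1cc(-c2cc(COCc3cn(Cc4cc(-c5ccc(C)cc5)cnc4Cl)nn3)on2)cc(OC)c1OC`: 58400 nM
Compound 3, `COc1cc(C2=NOC(COCc3cn(Cc4cc(-c5ccccc5)cnc4Cl)nn3)C2)cc(OC)c1OC`: 14600 nM

Of the compounds shown here, three have been measured in a functional assay on MCF7 cells (Homo sapiens) for cytotoxicity, read by MTT assay, with a stated time of 48 h; a higher number here means a weaker inhibitor, a lower number a stronger inhibitor. Compound 1 and compound 2 share one core and differ in a single place, (methyl in place of hydrogen on an aromatic carbon). This change gave a 1.2-fold lower number from compound 1 to compound 2 (0.07 log units; within the scatter), so the two values tell nothing of a real difference between them.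

Compound 3 carries a different core; how its core differs from that of compound 1 is not broken down here. In this assay compound 3 gives 14600 nM, the lowest of the three numbers and beyond the scatter of both compound 1 and compound 2.

Compound 4, `COc1cc(C2=NOC(COCc3cn(Cc4cc(-c5ccc(C)cc5)cnc4Cl)nn3)C2)cc(OC)c1OC`, has not yet been measured. It stands to compound 3 as compound 2 stands to compound 1: methyl in place of hydrogen on an aromatic carbon. The place lines for the two changes read alike, so this is the same change, made on the core of compound 3 instead of the core of compound 1. Among the compounds with values here, the only guide to its effect is the pair of compound 1 and compound 2, where the step stayed within the scatter. On that basis, the expected step in this assay from compound 3 to compound 4 is a 1.1-fold lower number from compound 3 to compound 4 (0.05 log units; within the scatter). Compound 4 is therefore estimated at 13000 nM, with a likely range from 6000 nM to 28000 nM. This rests on one pair only, and a different outcome on the core of compound 3 cannot be excluded.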

Compound 4, half-maximal inhibitory concentration: 12900 nM
Beside the measured number, compound 4's estimate is 1.0-fold (0.00 log units) above it, within the range that was stated.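

The change from phenyl to 4-methylphenyl gave a 1.1-fold lower number from compound 3 to compound 4 (0.05 log units; within the scatter) in this assay, so adding this methyl produced no readable difference on this core either. The same change therefore reads alike on the two cores, with neither step separable from the ordinary noise of the measurement: the same change on two cores in this assay, a 1.2-fold lower number (0.07 log units; within the scatter) from compound 1 to compound 2 and a 1.1-fold lower number (0.05 log units; within the scatter) from compound 3 to compound 4, 1.0-fold (0.02 log units) apart, within the scatter of two such steps. This shows that, on these two cores, a methyl at this place, para to a large group, leaves the cytotoxicity reading effectively unchanged, but both steps lie within the scatter, so a small real effect could be hidden in either, and agreement between two near-zero steps is a weaker test of transfer than agreement between two large steps would be, and it says nothing about a third core.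

The compounds shown leave open whether any other group at this place, such as a chlorine, a methoxy, an amine or a carboxylic acid, would shift the number beyond the scatter on either core. They also leave open whether a longer chain in place of the methyl would still behave alike on the two cores.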